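Removing the Ring Nitrogen Methyl from Compound 2

The source may report more compounds than this note shows. Statements on the series, on what has been measured and on what is new or still open speak of the compounds shown alone.

Compound 2 `COC(=O)[C@@H]1CN(C)CC[C@H]1c1ccc2ccccc2c1` gives 209 nM in a functional assay (brain) with Rattus norvegicus as the target (a lower number here means a stronger inhibitor, a higher number a weaker inhibitor), the higher of the two numbers available; its nearest neighbour, compound 1 `COC(=O)[C@@H]1CN(C)CC[C@@H]1c1ccc2ccccc2c1`, gives 8.2 nM in this assay. Among the compounds with values here, the only measured step, a 25-fold higher number from compound 1 to compound 2 (1.41 log units; beyond the scatter), rests on the fact that compounds 1 and 2 differ only in the configuration as drawn and says nothing about the change to compound 3 `COC(=O)[C@@H]1CNCC[C@H]1c1ccc2ccccc2c1`, which is hydrogen in place of methyl on an amine nitrogen in a ring. Within the data shown here, with no measured step bearing on this change, a step no larger than the scatter is expected, in either direction. Compound 3 is therefore estimated at 160 nM, between 50 nM and 600 nM. The expected step is a 1.3-fold lower number from compound 2 to compound 3 (0.12 log units; within the scatter).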

Compound 3, half-maximal inhibitory concentration: 3.9 nM
Estimate against measurement, compound 3: 41-fold (1.61 log units) above, outside the stated range (below it).
By their numbers in this assay, from the lowest: compound 3; then compound 1; then compound 2.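

In this assay, hydrogen in place of methyl on the amine nitrogen in a ring proves far from neutral in this series: the change gives a 54-fold lower number from compound 2 to compound 3 (1.73 log units; beyond the scatter) in the configuration of compound 2. Earlier, only a change of configuration had been seen to move the number; the group on this nitrogen now does so as well. Nothing available accounts for the size of this step. Still open, on these data alone, is whether ethyl or a longer chain on this nitrogen would give a similarly low number, and whether the same change starting from compound 1 would give a step of similar size.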